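Swapping the aryl group on a piperazine ligand

The source may report more compounds than this note shows. Statements on the series, on what has been measured and on what is new or still open speak of the compounds shown alone.

For the measured compounds named here, compound 1, with the structure `COc1ccc2c(c1)C(CCCN1CCN(c3cccc(C(F)(F)F)c3)CC1)CCC2`, is the only member of this small set with a number behind it. In an assay on isolated protein (Cavia porcellus) for binding affinity to Sigma non-opioid intracellular receptor 1 (Homo sapiens), read by radioligand binding (on this read-out lower numbers stand for stronger inhibition and higher numbers for weaker inhibition), compound 1 gives 87.5 nM, so it stands alone as the reference point; there is no second value to rank it against. Compound 2, with the structure `COc1ccccc1N1CCN(CCCC2CCCc3ccccc32)CC1`, belongs to the same series, but in this assay compound 2 shows "not tested" (no result reported), and nothing can be said about how it compares.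

Compound 3, with the structure `COc1ccc2c(c1)C(CCCN1CCN(c3ccccn3)CC1)CCC2`, shares the core of compound 1 and differs in one spot: pyridin-2-yl in place of 3-(trifluoromethyl)phenyl on an amine nitrogen in a ring. Going by the values given here, no measured pair in the set shows what this kind of exchange does. The expectation therefore has to rest on compound 1 alone and on the change itself. The step from compound 1 to compound 3 is expected to be a 2.9-fold higher number from compound 1 to compound 3 (0.46 log units; beyond the scatter), a modest loss of affinity that probably reaches slightly past the usual scatter but stays in the same order of magnitude. For compound 3 the estimate in this assay is 250 nM, with a likely range from 80 nM to 800 nM.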

Compound 3, half-maximal inhibitory concentration: 125 nM
Compound 3: middle estimate off by 2.0-fold (0.30 log units), on the high side, within the range that was stated.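

In this assay, for the compounds shown here, this is the first measured pair in the set, and it shows that pyridin-2-yl can take the place of 3-(trifluoromethyl)phenyl on the amine nitrogen in the ring, with a 1.4-fold higher number from compound 1 to compound 3 (0.15 log units; within the scatter), so the two compounds cannot be told apart on this read-out. This position therefore accepts a group with fewer heavy atoms, one ring nitrogen and one hydrogen-bond acceptor without a change beyond the usual scatter, although the pair alters all of these at once and cannot assign any part of the outcome to one of them. Nothing among the available data bears on why the two groups read alike.

A plain phenyl group at this place would help separate the role of the trifluoromethyl group from that of the ring nitrogen, and pyridin-3-yl or pyridin-4-yl would show whether the location of that nitrogen matters. From the compounds shown here alone, it also remains open whether the same exchange would read alike on a compound with a longer chain between the shared core and the piperazine.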